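Changing the aryl group: expectation for compound 3

The source may report more compounds than this note shows. Statements on the series, on what has been measured and on what is new or still open speak of the compounds shown alone.

Compound 1 `Nc1scc(CN2CCN(c3ccc(F)cc3Cl)CC2)c1C(=O)c1ccc(Cl)cc1`: -70%
Compound 2 `Nc1scc(CN2CCN(c3ccc(F)c(F)c3)CC2)c1C(=O)c1ccc(Cl)cc1`: -87%

In a functional assay on CHO cells with adenosine receptor A1 (Homo sapiens) as the target, read by cAMP accumulation and immunoassay, with a stated time of 6 min, tested at 10 uM (on this read-out higher numbers stand for a weaker effect at the one concentration tested and lower numbers for a stronger effect), compound 1 gives -70%, the highest of the two numbers; the nearest is compound 2 with -87%. Compound 3 `Nc1scc(CN2CCN(c3c(F)cc(F)cc3F)CC2)c1C(=O)c1ccc(Cl)cc1` differs from compound 1 by 2,4,6-trifluorophenyl in place of 2-chloro-4-fluorophenyl on an amine nitrogen in a ring. For the measured compounds named here, the only measured step, a number 17 percentage points lower from compound 1 to compound 2 (beyond the scatter), also exchanges the aryl group on that same nitrogen and was modest, beyond the scatter. A step of comparable size is therefore expected, but the data leave its direction open. Compound 3 is expected to give -75%, within -97% to -50%, an expected step of a number 5 percentage points lower from compound 1 to compound 3 (within the scatter).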

Compound 3, a percentage reported as activity, at one concentration (the size of the read-out at that concentration, not a potency): -78%
Estimate against measurement, compound 3: 3 percentage points above; the measured number falls inside the stated range.
By their numbers in this assay, from the lowest: compounds 2, 3 and 1 (each within the scatter of the next, the first and the last beyond it).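

In this assay the 2,4,6-trifluorophenyl group gives a number 8 percentage points lower from compound 1 to compound 3 (within the scatter) and a number 9 percentage points higher from compound 2 to compound 3 (within the scatter) and so cannot be separated from either earlier aryl group, although compound 1 and compound 2 stand apart. This position on the amine nitrogen therefore accepts a third halogenated phenyl group with a reading close to both others. Nothing available explains these readings. The compounds shown leave open how a phenyl group bearing methoxy or nitrile, or a saturated cyclohexyl ring, would read on the same nitrogen.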